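Repositioning the methoxyphenyl on a sulfonamide series

The source may hold more compounds than are shown below. What is called first, only, known or untested is meant among the compounds shown, and "the series" means these compounds.

Compound 1 `O=S(=O)(Nc1ccc(-c2nc3ccccc3o2)cc1)c1ccc(F)c(C(F)(F)F)c1`: > 63000 nM
Compound 2 `COc1ccc(S(=O)(=O)Nc2ccc(-c3nc4ccccc4o3)cc2)cc1`: > 63000 nM
Compound 3 `O=S(=O)(Nc1ccc2oc(-c3ccccc3)nc2c1)c1cccs1`: > 63000 nM

In an assay on isolated protein for inhibition of malate dehydrogenase, mitochondrial (Sus scrofa), with stated times of 45 min and 30 min (on this read-out lower numbers stand for stronger inhibition and higher numbers for weaker inhibition), compound 2 gives only a limit of the assay, > 63000 nM, and no number. The same holds for compound 1 and for compound 3, as the limit of > 63000 nM in this assay, at which 3 of the 3 values shown sit, records. Compound 4 `COc1ccccc1S(=O)(=O)Nc1ccc(-c2nc3ccccc3o2)cc1` has not been measured in this assay. It differs from compound 2 by 2-methoxyphenyl in place of 4-methoxyphenyl on a sulfonyl sulfur. With every measured value sitting at the limit, there is no step between measured compounds to calibrate the change, and nothing among these three points to a gain. Compound 4 is therefore expected to return another limit rather than a number, an estimate of 80000 nM with a range from 20000 nM to 300000 nM, meaning an expected step that the limit leaves unreadable from compound 2 to compound 4.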

Compound 4, half-maximal inhibitory concentration: > 63000 nM
Compound 4: only a limit was reported; the forecaster's own chance of this, stated with the estimate: 85%; the middle value lies beyond the limit too.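

Among the compounds shown here, compound 2 and compound 4 each give only a limit of the assay, and no step between them can be read. The compounds shown leave open whether any group on the sulfonyl sulfur yields a measurable inhibition.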